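Swapping a nitrogen link for an oxygen link

The source may report more compounds than this note shows. Statements on the series, on what has been measured and on what is new or still open speak of the compounds shown alone.

Compound 1 `CCOC(=O)CCNc1cc(Nc2ccc3[nH]c(=O)[nH]c3c2)c(Cl)cc1[N+](=O)[O-]`: 0.42 ug/mL
Compound 2 `O=c1[nH]c2ccc(Nc3cc(NC4CCOCC4)c([N+](=O)[O-])cc3Cl)cc2[nH]1`: 0.61 ug/mL

In a physicochemical assay for solubility, read by spectrophotometry, at pH 6.8 (on this read-out higher numbers stand for higher solubility and lower numbers for lower solubility), compound 2 gives 0.61 ug/mL, a value that cannot be told apart from that of compound 1. Compound 3 `O=c1[nH]c2ccc(Nc3cc(OC4CCOCC4)c([N+](=O)[O-])cc3Cl)cc2[nH]1` carries one change: (oxan-4-yl)oxy in place of (oxan-4-yl)amino on an aromatic carbon, with (oxan-4-yl)oxy in place of (oxan-4-yl)amino on an aromatic carbon. For the measured compounds named here, the only measured step is a 1.5-fold higher number from compound 1 to compound 2 (0.16 log units; within the scatter). It swapped the group on a nitrogen and kept the nitrogen itself, so it is only a loose guide here. No shift beyond the scatter is therefore expected in this assay. The expected change is a 1.2-fold lower number from compound 2 to compound 3 (0.09 log units; within the scatter). For compound 3 the estimated value is 0.5 ug/mL, with an expected range from 0.2 ug/mL to 1.3 ug/mL.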

Compound 3, solubility: 18 ug/mL
Compound 3: the middle estimate sits 36-fold (1.56 log units) below what was measured, outside the stated range (above it).
By their numbers in this assay, from the lowest: compounds 1 and 2 (each within the scatter of the next); then compound 3.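

With the oxan-4-yl ring kept, changing only the linking atom at this position, ortho to a nitro group, gives a 30-fold higher number from compound 2 to compound 3 (1.47 log units; beyond the scatter) in this assay and takes 1 hydrogen-bond donor down to 0. The step of a 43-fold higher number from compound 1 to compound 3 (1.63 log units; beyond the scatter) is equally large, whereas changing the group while keeping the nitrogen link stayed within the scatter. No measurement available here accounts for this jump. On these data alone, it remains open whether a sulfur link or a methylated nitrogen link would match the oxygen link, and whether the oxygen link gives a similar step when it carries a carboxylic acid chain instead of the oxan-4-yl ring.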